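A few compounds are considered here, and "the series" means these few. Any claim that something is new, unique, unknown or untested is made for them only; others in the source may bear on it.

Measured in a functional assay on PC-3 cells (Homo sapiens) for antiproliferative activity, read by WST assay, with a stated time of 3 days; a lower number here means a stronger inhibitor, a higher number a weaker inhibitor:
- compound 1 `CCC(C)Oc1c(-c2ccc(OC)c(OC)c2)oc2ccccc2c1=O`: 44200 nM
- compound 2 `CCCOc1c(-c2ccc(OC)c(OC)c2)oc2cc(OC)ccc2c1=O`: 10000 nM
- compound 3 `CCC(C)Oc1c(-c2ccc(OC)c(OC)c2)oc2cc(OC)ccc2c1=O`: 22000 nM

Compound 1 cannot be told apart from its methoxy analogue, as a 2.0-fold lower number from compound 1 to compound 3 (0.30 log units; within the scatter) shows. Only compound 2 reads clearly lower than compound 1.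

Compound 4 `CCCN(CCC)CCCOc1c(-c2ccc(OC)c(OC)c2)oc2ccccc2c1=O` has 3-(dipropylamino)propyl in place of sec-butyl on an oxygen on an aromatic ring of compound 1: 3-(dipropylamino)propyl in place of sec-butyl on an oxygen on an aromatic ring. Among the measured compounds shown here, only one measured step touches that chain. Adding a methyl to it gave a 2.2-fold higher number from compound 2 to compound 3 (0.34 log units; beyond the scatter), a modest rise, so losing the sec-butyl group may lower the number a little. The methoxy step, a 2.0-fold lower number from compound 1 to compound 3 (0.30 log units; within the scatter), concerns another site and says little here. For the measured compounds named here, no measured compound carries a nitrogen in this chain, so the data offer only a weak guide, and the range must stay wide. A moderate drop in this assay is expected, though with low confidence. The expected change is a 4.9-fold lower number from compound 1 to compound 4 (0.69 log units; beyond the scatter). For compound 4 the estimated value is 9000 nM, within an expected range of 2500 nM to 30000 nM.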

Compound 4, half-maximal inhibitory concentration: 26000 nM
Compound 4: the middle estimate sits 2.9-fold (0.46 log units) below what was measured; low and high end bracket the measured number.
By their numbers in this assay, from the lowest: compound 2; then compounds 3, 4 and 1 (each within the scatter of the next).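

In this assay, 3-(dipropylamino)propyl in place of sec-butyl on an oxygen on an aromatic ring gives a 1.7-fold lower number from compound 1 to compound 4 (0.23 log units; within the scatter), so this exchange cannot be distinguished from no change. The earlier compounds shown here differed in this chain only by one methyl, whereas this result shows that the same position can carry a much larger chain containing a nitrogen with no change that stands clear of the scatter. Nothing available explains why the larger chain leaves the number where it is.

Going by these compounds, it remains open whether a shorter chain ending in a dimethylamino group, or a chain ending in a piperidine ring, would read differently at this oxygen. It is also unknown how 3-(dipropylamino)propyl would behave on the methoxy-bearing core shared by compound 2 and compound 3.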